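The compounds below may be only part of what the source reports. "The series", "measured", "known", "first", "only" and "open" are said of these compounds alone.

Among the compounds with values here, compound 2 `O=C(Nc1ccc(OC(F)(F)F)cc1)N1CCN(c2ncccc2Cl)CC1` stands at the highest of the two numbers so far in a functional assay on HEK293 cells for antagonist activity at transient receptor potential cation channel subfamily V member 1 (Rattus norvegicus) (a higher number here means a weaker inhibitor, a lower number a stronger inhibitor), giving 261 nM, while compound 1 `O=C(Nc1ccc(C(F)(F)F)cc1)N1CCN(c2ncccc2Cl)CC1` gives 81.4 nM. Within the data shown here, the one measured step, a 3.2-fold higher number from compound 1 to compound 2 (0.51 log units; beyond the scatter), is the only step that bears on the next change, and it covers neither bromo nor the removal of the oxygen. Compound 3 `O=C(Nc1ccc(Br)cc1)N1CCN(c2ncccc2Cl)CC1` carries bromo in place of trifluoromethoxy on an aromatic carbon. Compound 3 is expected to move back toward the number of compound 1. The number for compound 3 is therefore expected to fall by a 2.4-fold lower number from compound 2 to compound 3 (0.38 log units; beyond the scatter). Compound 3 is estimated at 110 nM, between 35 nM and 400 nM.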

Compound 3, half-maximal inhibitory concentration: 1010 nM
Compound 3: the middle estimate sits 9.2-fold (0.96 log units) below what was measured; measured number outside the range, above it.
By their numbers in this assay, from the lowest: compound 1; then compound 2; then compound 3.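

At this place, on an aromatic carbon para to a large group, bromo is the weakest of the three groups in this assay, with a 3.9-fold higher number from compound 2 to compound 3 (0.59 log units; beyond the scatter) and a 12-fold higher number from compound 1 to compound 3 (1.09 log units; beyond the scatter). The range at this position is thus much wider than the first two compounds showed, and a single bromine does not stand in for either fluorinated group. Nothing shown accounts for this loss. On these data alone, whether chloro, methyl or a nitrile would behave like bromo or like trifluoromethyl remains open.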